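The source may hold more compounds than are shown below. What is called first, only, known or untested is meant among the compounds shown, and "the series" means these compounds.

Compound 1, `CC(C)N(Cc1cccc(OCCCCCC(=O)O)c1)C(=O)c1ccc(-c2ccncc2)cc1`, is the starting point of this account. In an ADME assay on HEK293 cells (Homo sapiens) for cytotoxicity, read by CellTiter-Glo and resazurin assay, with a stated time of 72 h (on this read-out higher numbers stand for an effect only at larger amounts of compound and lower numbers for an effect already at smaller amounts), compound 1 gives > 26000 nM, which is a limit of the assay and not a measured number. Compound 2, `CC(C)Oc1cccc(-c2ccc(C(=O)N(Cc3cccc(OCCCCCC(=O)O)c3)C(C)C)cc2)c1`, carries a 3-isopropoxyphenyl in place of the pyridin-4-yl of compound 1. In this assay compound 2 gives > 26000 nM, again a limit. Compound 3, `CC(C)N(Cc1cccc(OCCCCCC(=O)O)c1)C(=O)c1ccc(-c2cccc(OCc3ccccc3)c2)cc1`, carries a benzyl in place of the isopropyl on the oxygen on the aromatic ring of compound 2. In this assay compound 3 gives > 26000 nM, also a limit. The step that the two limits leave unreadable from compound 1 to compound 2 cannot be read, and neither can a step that the two limits leave unreadable from compound 2 to compound 3, because of the limit of > 26000 nM in this assay, at which 3 of the 3 values shown sit.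

Compound 4, `CC(C)N(Cc1cccc(OCCCCCC(=O)O)c1)C(=O)c1ccc(-c2ccc3[nH]ccc3c2)cc1`, is not yet measured in this assay. It differs from compound 1 in one place: 1H-indol-5-yl in place of pyridin-4-yl on an aromatic carbon. Both measured steps that bear on changes at this position leave the size unreadable, so the change in compound 4 cannot be judged from them; no step beyond the scatter can be predicted in either direction. Compound 4 is expected to behave like compound 1, with an estimated step that the limit leaves unreadable from compound 1 to compound 4. Compound 4 is therefore estimated at 30000 nM, within a range from 12000 nM to 80000 nM, and most likely the assay will again report only a limit.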

Compound 4, half-maximal effective concentration: > 26000 nM
Compound 4 gave a limit, no number (the forecaster's own chance of this, stated with the estimate: 80%); the middle value lies beyond the limit too.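

No step can be read from compound 1 to compound 4 or from compound 2 to compound 4 in this assay, because all the values are limits and not numbers: the limit of > 26000 nM in this assay, at which 4 of the 4 values shown sit. The compounds shown leave open whether pyridin-4-yl, 3-isopropoxyphenyl and 1H-indol-5-yl differ at all on this read-out.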